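Amide to urea swap in a thiazole alkyne series

The compounds below may be only part of what the source reports. "The series", "measured", "known", "first", "only" and "open" are said of these compounds alone.

compound 1 `O=C1NCCc2nc(C#Cc3ccccc3F)sc21`: > 10000 nM
compound 2 `COC1CC(C(=O)N2CCc3nc(C#Cc4ccccc4)sc3C2)C1`: > 10000 nM
compound 3 `CC(C)S(=O)(=O)N1Cc2nc(C#Cc3ccccc3)sc2C1`: 140 nM

In an assay on HEK293 cells for negative allosteric modulation of metabotropic glutamate receptor 5 (Homo sapiens), read by FLIPR, with a stated time of 1 h (on this read-out higher numbers stand for weaker inhibition and lower numbers for stronger inhibition), compound 1 gives > 10000 nM, a limit of the assay and not a number. Compound 2 likewise gives > 10000 nM in this assay, again only a limit. Compound 3 gives 140 nM. Compound 2 therefore stands at the limit of > 10000 nM in this assay, at which 2 of the 3 values shown sit, the same limit as compound 1, with only compound 3 giving a number. For the measured compounds named here, no two measured compounds differ in one place, so no measured step is available. Compound 4 `O=C(N1CCCCC1)N1CCc2nc(C#Cc3ccccc3)sc2C1` differs from compound 2 thus: piperidin-1-yl in place of 3-methoxycyclobutyl on a carbonyl carbon. The shared core and the amide-type nitrogen in a ring stay. The expected step is an at least 3.3-fold lower number from compound 2 to compound 4 (0.52 log units; beyond the scatter), a gain beyond the scatter but with wide uncertainty. Compound 4 is estimated at 3000 nM, from 400 nM to 20000 nM.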

Compound 4, half-maximal inhibitory concentration: > 10000 nM
Compound 4 was reported as a limit; the forecaster's own chance of this, stated with the estimate: 45%; middle value at least 3.3-fold (0.52 log units) from the limit.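

For the compounds shown here, compound 2 and compound 4 both sit at a limit, so no step between them can be read: the limit of > 10000 nM in this assay, at which 3 of the 4 values shown sit. The compounds shown leave open whether piperidin-1-yl in place of 3-methoxycyclobutyl on a carbonyl carbon changes inhibition at all.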